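Small ester variation on a crown-ether carrier against WiDr cells

The source may hold more compounds than are shown below. What is called first, only, known or untested is meant among the compounds shown, and "the series" means these compounds.

Measured so far in a functional assay on WiDr cells (Homo sapiens) for inhibition, read by sulforhodamine B assay, with a stated time of 48 h; on this read-out higher numbers stand for weaker inhibition of growth and lower numbers for stronger inhibition of growth:
compound 1 `CC(C)=CC1C(C(=O)OCC2COCCOCCOCCOCCOCCO2)C1(C)C` gives 56000 nM.
compound 2 `O=C(CCCCc1ccccc1)OCC1COCCOCCOCCOCCOCCO1` gives only a limit, > 100000 nM.

Compound 2 thus stands at the limit of the read-out, as shown by the limit of > 100000 nM in this assay, at which 1 of the 2 values shown sits. The step of an at least 1.7-fold higher number from compound 1 to compound 2 (0.25 log units; that floor lies within the scatter) is the only measured one and it bears directly on this change; it shows no clear movement. Compound 3 `O=C(OCC1COCCOCCOCCOCCOCCO1)c1cccnc1` differs from compound 2 by pyridin-3-yl in place of 4-phenylbutyl on a carbonyl carbon. Within the data shown here, with no measured step that separates from the scatter, compound 3 is expected to remain near the limit, with an expected step that the limit leaves unreadable from compound 2 to compound 3. Compound 3 is estimated at 150000 nM, between 40000 nM and 500000 nM.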

Compound 3, concentration for 50% growth inhibition: > 100000 nM
Compound 3: a limit, no number; the forecaster's own chance of this, stated with the estimate: 70%; the middle value does not contradict the limit.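

In this assay compound 3 gives > 100000 nM, which is a limit and not a number. Among these compounds, the step between the two limits cannot be read, and the one readable step is an at least 1.7-fold higher number from compound 1 to compound 3 (0.25 log units; that floor lies within the scatter). With pyridin-3-yl in place of 4-phenylbutyl on the carbonyl carbon, the read-out still gives no number: the limit of > 100000 nM in this assay, at which 2 of the 3 values shown sit.

The compounds shown leave open whether an amine or a carboxylic acid on the group at this carbonyl carbon would give a number within the read-out. They also leave open how far compound 2 and compound 3 lie beyond the limit.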